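This account rests on a few compounds, and the source may have more. Where it says the series, first, only, none or still open, it means among the compounds named here.

Within the data shown here, in an assay on HT-29 cells for inhibition of Serine-protein kinase ATM (Homo sapiens), read by fluorescence, with a stated time of 1 h (a higher number here means a weaker inhibitor, a lower number a stronger inhibitor), compound 2 `CCC(CC)CNc1c(C(N)=O)cnc2ccc(-c3cccnc3)cc12` gives 73 nM, the only number in this set. Compound 1 `C[C@@H](Nc1c(C(=O)O)cnc2ccc(-c3cccnc3)cc12)c1ccc(Cl)cc1` reaches only a limit of the assay, > 30000 nM, and so cannot be placed against it; this is the case described by the limit of > 30000 nM in this assay, at which 1 of the 2 values shown sits. The unmeasured compound 3 `C[C@H](Nc1c(C(N)=O)cnc2ccc(-c3cccnc3)cc12)C1CCOCC1` differs from compound 2 by 1-(oxan-4-yl)ethyl in place of 2-ethylbutyl on a nitrogen on an aromatic ring. Among the measured compounds shown here, no measured pair covers this change, so the expected step, a 1.2-fold lower number from compound 2 to compound 3 (0.09 log units; within the scatter), is taken to lie within the usual scatter in either direction. Compound 3 is therefore expected to give about 60 nM, with a likely range from 15 nM to 300 nM.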

Compound 3, half-maximal inhibitory concentration: 168 nM
For compound 3 the middle estimate is 2.8-fold (0.45 log units) below the measured one; measured number inside the range.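

In this assay the swap of 2-ethylbutyl for 1-(oxan-4-yl)ethyl on a nitrogen on an aromatic ring gives a 2.3-fold higher number from compound 2 to compound 3 (0.36 log units; beyond the scatter) and so a modest loss of strength. Among these compounds, this is the first step that can be read at this position, and it shows that the position takes a group carrying a six-membered non-aromatic ring at only a modest cost. Nothing shown here gives a reason for the step. As far as these compounds go, it remains open whether a cyclohexyl group, or a piperidine with a nitrogen in place of the ring oxygen, would behave like the oxan-4-yl group.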